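This account rests on a few compounds, and the source may have more. Where it says the series, first, only, none or still open, it means among the compounds named here.

Working notes on the series. In a functional assay on WM 266-4 cells (Homo sapiens) for antiproliferative activity, read by MTT assay, with a stated time of 24 h (a higher number here means a weaker inhibitor of growth, a lower number a stronger inhibitor of growth), compound 1 (`COc1ccc(C2CC(c3ccc4c(c3)OCCO4)=NN2c2ccccc2)cc1OC`) gives 2160 nM and compound 2 (`CSc1ccc(C2CC(c3ccc4c(c3)OCCO4)=NN2c2ccccc2)cc1`) gives 6870 nM as the higher of the two numbers, a gap beyond the scatter. Compound 3 (`Clc1cccc(C2CC(c3ccc4c(c3)OCCO4)=NN2c2ccccc2)c1`) is still unmeasured. It carries 3-chlorophenyl in place of 4-(methylsulfanyl)phenyl on a saturated ring carbon and keeps the shared core unchanged. Among the measured compounds shown here, the one measured step at this same carbon is a 3.2-fold higher number from compound 1 to compound 2 (0.50 log units; beyond the scatter) and it is modest. For the measured compounds named here, no compound with 3-chlorophenyl has been measured, and that step gives a scale but no direction. Going by the values given here, compound 2 at 6870 nM stands highest of only two numbers, which leans the expectation for compound 3 toward a lower number, by less than the measured step and probably not beyond the scatter. The estimated change is a 1.5-fold lower number from compound 2 to compound 3 (0.18 log units; within the scatter) in this assay and rests on a single step. For compound 3 the expected value is 4500 nM with an estimated range from 1600 nM to 12000 nM as its bounds.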

Compound 3, concentration for 50% growth inhibition: 1750 nM
For compound 3 the middle estimate is 2.6-fold (0.41 log units) above the measured one; measured number inside the range.
By their numbers in this assay, from the lowest: compounds 3 and 1 (each within the scatter of the next); then compound 2.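

Replacing 4-(methylsulfanyl)phenyl with 3-chlorophenyl on the saturated ring carbon gives a 3.9-fold lower number from compound 2 to compound 3 (0.59 log units; beyond the scatter) in this assay, so the number at this carbon can fall as well as rise, and compound 2 now stands apart from two other aryl groups rather than being merely the higher of a pair. The two groups that share a substituent at the ring position numbered 3, one with a single chlorine and the other with two methoxy groups, do not separate, with a 1.2-fold lower number from compound 1 to compound 3 (0.09 log units; within the scatter), so this carbon accepts quite different substituents on the aryl ring without a change beyond the scatter. Among these three compounds, the group with a substituent numbered 4 alone gives the higher number, but nothing available explains that difference or the lack of one between compound 1 and compound 3.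

The compounds shown leave open whether the placement or the kind of substituent sets these numbers, since 4-chlorophenyl and 3-(methylsulfanyl)phenyl are absent from the comparison. From the compounds shown here alone, it also remains open how an unsubstituted phenyl, or an aryl group bearing an amine or a carboxylic acid, would read at this carbon.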